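A few compounds are considered here, and "the series" means these few. Any claim that something is new, unique, unknown or untested is made for them only; others in the source may bear on it.

Compound 1 `C=C1C(=O)[C@]23C[C@@]1(O)CC[C@H]2c1ccc(O)c(C)c1[C@@H]3Cn1cc(-c2ccccc2)nn1`: 260 nM
Compound 2 `C=C1C[C@]23C[C@@]1(O)CC[C@H]2c1ccc(O)c(C)c1[C@@H]3Cn1cc(-c2ccc(C(F)(F)F)cc2)nn1`: > 20000 nM

In a functional assay on SW480 cells (Homo sapiens) for cytotoxicity, read by MTT assay, with a stated time of 4 days (on this read-out higher numbers stand for weaker inhibition and lower numbers for stronger inhibition), compound 1 gives 260 nM. For compound 2 the assay reports only a limit, > 20000 nM, which is the limit of > 20000 nM in this assay, at which 1 of the 2 values shown sits. The two numbers show compound 1 clearly active and compound 2 not measurably so in the tested range. Compound 3 `C=C1C[C@]23C[C@@]1(O)CC[C@H]2c1ccc(O)c(C)c1[C@@H]3Cn1cc(-c2ccc(OC)cc2)nn1` is not yet measured and differs from compound 2 by methoxy in place of trifluoromethyl on an aromatic carbon. Going by the values given here, no measured step covers such a change, so no direction is known. Compound 3 is expected to remain weak, at an estimated 15000 nM, between 3000 nM and 60000 nM. That expectation amounts to a step of an at least 1.3-fold lower number from compound 2 to compound 3 (0.12 log units; that floor lies within the scatter).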

Compound 3, half-maximal inhibitory concentration: > 20000 nM
Compound 3 was reported as a limit; the forecaster's own chance of this, stated with the estimate: 60%; at least 1.3-fold (0.12 log units) between middle value and limit.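

Compound 2 and compound 3 both stop at a limit rather than a number, so no step can be read between them: the limit of > 20000 nM in this assay, at which 2 of the 3 values shown sit.

Going by these compounds, whether methoxy or trifluoromethyl gives the stronger inhibition stays open.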